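The source may report more compounds than this note shows. Statements on the series, on what has been measured and on what is new or still open speak of the compounds shown alone.

Measured in an ADME assay on the whole organism (strain Sprague-Dawley) for pharmacokinetics, with Rattus norvegicus as the target, at a dose of 5 mg/kg by the oral route; on this read-out higher numbers stand for higher exposure at the dose given and lower numbers for lower exposure:
- compound 1 `COc1c(C(=O)Nc2ccc(NS(C)(=O)=O)cc2)cc(N2CCC(=O)NC2=O)cc1C(C)(C)C`: 61.4 nM
- compound 2 `COc1c(/C=C/c2ccc(NS(C)(=O)=O)cc2)cc(N2CCC(=O)NC2=O)cc1C(C)(C)C`: 551 nM

In this assay compound 2 gives 551 nM, the higher of the two numbers and beyond the scatter from compound 1.

Compound 3 `COc1c(/C=C/c2ccc(NS(C)(=O)=O)cc2)cc(-n2ccc(=O)[nH]c2=O)cc1C(C)(C)C` differs from compound 2 in one place: a group of 8 heavy atoms (4 carbon, 2 nitrogen, 2 oxygen; one six-membered aromatic ring with 2 hetero atoms) in place of a group of 8 heavy atoms (4 carbon, 2 nitrogen, 2 oxygen; one six-membered non-aromatic ring with 2 hetero atoms), on an aromatic carbon. A six-membered aromatic ring with 2 hetero atoms takes the place of the six-membered non-aromatic ring, on an aromatic carbon. Among the measured compounds shown here, no measured step covers this change, so the expectation is loose. The expected 1.4-fold lower number from compound 2 to compound 3 (0.14 log units; within the scatter) stays within the scatter. For compound 3 the estimated value is 400 nM, with an expected range of 100 nM to 1500 nM.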

Compound 3, maximal plasma concentration in the Rattus norvegicus assay: 596 nM
The estimate for compound 3 lay 1.5-fold (0.17 log units) below the measured number; low and high end bracket the measured number.
By their numbers in the Rattus norvegicus assay, from the lowest: compound 1; then compounds 2 and 3 (each within the scatter of the next).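

In the Rattus norvegicus assay compound 2 gives 551 nM and compound 3 gives 596 nM; this position, para to the methoxy group, accepts the six-membered aromatic ring with 2 hetero atoms in place of the non-aromatic ring without a step beyond the scatter: a 1.1-fold higher number from compound 2 to compound 3 (0.03 log units; within the scatter). In a physicochemical assay for solubility, at pH 7.2 (on this read-out higher numbers stand for higher solubility and lower numbers for lower solubility), compound 2 gives 10300 nM and compound 3 gives 20700 nM; the same replacement gives a 2.0-fold higher number from compound 2 to compound 3 (0.30 log units; within the scatter), so neither read-out separates the two compounds. Nothing available gives a reason for either result.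

Going by these compounds, whether an amine or a carboxylic acid on this aromatic carbon would keep the exposure of compound 3 remains open. Also open, on these data alone, is whether the aromatic ring would do so alongside the amide of compound 1.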